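Swapping Chloro for Fluoro on a Triazole Benzyl Arm

The source may hold more compounds than are shown below. What is called first, only, known or untested is meant among the compounds shown, and "the series" means these compounds.

Measured so far in a functional assay on ECa-109 cells (Homo sapiens) for inhibition, read by MTT assay, with a stated time of 72 h; on this read-out lower numbers stand for stronger inhibition and higher numbers for weaker inhibition:
compound 1 `N#Cc1c(Nc2ccccc2Cl)nc(SCc2cn(Cc3ccccc3Cl)nn2)nc1-c1ccccc1` gives 28500 nM
compound 2 `N#Cc1c(Nc2ccccc2F)nc(SCc2cn(Cc3ccccc3Cl)nn2)nc1-c1ccccc1` gives 23000 nM
compound 3 `Cc1ccc(Nc2nc(SCc3cn(Cc4ccc(Cl)cc4)nn3)nc(-c3ccccc3)c2C#N)cc1` gives > 64000 nM

Compounds 1 and 2 share one core and differ only by fluoro in place of chloro on an aromatic carbon. The step of a 1.2-fold lower number from compound 1 to compound 2 (0.09 log units; within the scatter) is small. For compound 3 this assay reports only a limit, not a number, so its position is open-ended. The difference between the cores of compound 1 and compound 3 is not broken down here.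

Compound 4 `Cc1ccc(Nc2nc(SCc3cn(Cc4ccc(F)cc4)nn3)nc(-c3ccccc3)c2C#N)cc1` is not yet measured. It comes from compound 3 by fluoro in place of chloro on an aromatic carbon. Within the data shown here, this is the same kind of change as the one from compound 1 to compound 2, but at a different place: ortho to a large group in the first pair, para to a large group here, and on the benzyl arm rather than on the aryl amine.

Because the earlier step of a 1.2-fold lower number from compound 1 to compound 2 (0.09 log units; within the scatter) stayed within the scatter, the expected step that the limit leaves unreadable from compound 3 to compound 4 is also small, and compound 4 is expected to sit near the same limit as compound 3 (the limit of > 64000 nM in this assay, at which 1 of the 3 values shown sits). The estimate for compound 4 is 80000 nM, spanning 30000 nM to 200000 nM.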

Compound 4, half-maximal inhibitory concentration: 42700 nM
Compound 4: middle estimate off by 1.9-fold (0.27 log units), on the high side, and the stated range covers the measured number.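

In this assay compound 3 gives > 64000 nM, which is a limit and not a number. Going from 4-chlorobenzyl to 4-fluorobenzyl gives an at least 1.4-fold lower number from compound 3 to compound 4 (0.17 log units; that floor lies within the scatter), and this figure is only a floor, so the true size of the step could be small or much larger. The swap sits on the benzyl arm in this pair and on the aryl amine in the earlier pair, and the data show neither that the change carries over from one core to the other with the same size nor that it behaves differently: the same change on two cores in this assay, a 1.2-fold lower number (0.09 log units; within the scatter) from compound 1 to compound 2 and an at least 1.4-fold lower number (0.17 log units; that floor lies within the scatter) from compound 3 to compound 4; the limit leaves it open whether they differ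

The compounds shown carry only chloro or fluoro in these swaps, so it remains open how a bromo, methoxy or trifluoromethyl group would read at the same places. From the compounds shown here alone, it is also open what a fluoro on the benzyl arm would do on the core of compound 1, where a matched pair would give two real numbers to compare.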